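Sulfur for oxygen in the aryl linker of compound 1

This account rests on a few compounds, and the source may have more. Where it says the series, first, only, none or still open, it means among the compounds named here.

Measured in a functional assay on LOX IMVI cells (Homo sapiens) for inhibition, read by sulforhodamine B assay, with a stated time of 48 h; a higher number here means a weaker inhibitor of growth, a lower number a stronger inhibitor of growth:
- compound 1, `Nc1cc(N)c2nc(-c3ccccc3)c(Oc3ccc(Cl)c(Cl)c3)nc2c1`: 33900 nM
- compound 2, `COc1ccc(CNc2nc3cc(N)cc(N)c3nc2-c2ccccc2)cc1OC`: 14100 nM
- compound 3, `COc1ccc(CNc2nc3cc(N)cc(N)c3nc2-c2ccccc2)cc1`: 27500 nM

Compound 1 carries the 3,4-dichlorophenoxy group; compounds 2 and 3 instead carry a benzylamine on the same core. The number for compound 1 lies beyond the scatter only from that of compound 2, and within the scatter of that of compound 3. Going by the values given here, the single step within the measured set, a 2.0-fold higher number from compound 2 to compound 3 (0.29 log units; within the scatter), concerns a methoxy group on the benzylamine side and not the linker.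

Compound 4, `Nc1cc(N)c2nc(-c3ccccc3)c(Sc3ccc(Cl)c(Cl)c3)nc2c1`, differs from compound 1 by (3,4-dichlorophenyl)sulfanyl in place of 3,4-dichlorophenoxy on an aromatic carbon. Among the compounds with values here, no measured step touches this oxygen-to-sulfur exchange, and the one step available, a 2.0-fold higher number from compound 2 to compound 3 (0.29 log units; within the scatter), lies elsewhere and is itself within the scatter. The expectation is therefore no step beyond the scatter, a 1.0-fold higher number from compound 1 to compound 4 (0.00 log units; within the scatter), with a wide band around it. Compound 4 is estimated at 34000 nM, between 12000 nM and 95000 nM.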

Compound 4, concentration for total growth inhibition: 24500 nM
The estimate for compound 4 lay 1.4-fold (0.14 log units) above the measured number, within the range that was stated.
By their numbers in this assay, from the lowest: compounds 2, 4, 3 and 1 (each within the scatter of the next, the first and the last beyond it).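

In this assay, going by these compounds alone, (3,4-dichlorophenyl)sulfanyl in place of 3,4-dichlorophenoxy on the shared core gives a 1.4-fold lower number from compound 1 to compound 4 (0.14 log units; within the scatter), the only step read at this position, and it stays within the scatter. At this aromatic carbon next to the ring nitrogen, oxygen and sulfur as the linking atom are therefore not separated by this read-out, which the earlier step on the methoxy group of the benzylamine side could not show. No measured evidence bears on this result.

Open, on these data alone, is whether a methylene or sulfonyl linker at this carbon would move the number beyond the scatter of compound 1. Also open, as far as these compounds go, is whether the 3,4-dichlorophenyl ring matters on the sulfur linker, for instance against a plain phenyl or a 4-methoxyphenyl group there.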